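An Ethyl-to-Cyclopropyl Swap on the Shared Core

The source may hold more compounds than are shown below. What is called first, only, known or untested is meant among the compounds shown, and "the series" means these compounds.

Compound 1 `CCn1nc(CC(=O)Nc2ccc(OC(F)(F)F)c(Cl)c2)c2ccccc2c1=O` gives 199 nM in a functional assay on CHO cells for antagonist activity at sphingosine 1-phosphate receptor 2 (Homo sapiens), read by calcium flux; a higher number here means a weaker inhibitor, a lower number a stronger inhibitor.
Compound 2 `O=C(O)C1(c2nn(Cc3cn4cc(OCC5CC5)c(Cl)cc4n3)c3ccccc3c2=O)CC1` gives 16 nM in this assay.
Compound 3 `CCC(C(=O)O)c1nn(Cc2cn3cc(OCC4CC4)c(Cl)cc3n2)c2ccccc2c1=O` gives 5.6 nM in this assay.

Among these three, compound 1 stands highest; compound 2 lies nearest to it and compound 3 furthest, both gaps beyond the scatter. Among the compounds with values here, the only step measured in one place, a 2.9-fold lower number from compound 2 to compound 3 (0.46 log units; beyond the scatter), concerns the carboxyl-bearing group on an aromatic carbon and leaves the substituent on the aromatic nitrogen untouched. Compound 4 `O=C(Cc1nn(C2CC2)c(=O)c2ccccc12)Nc1ccc(OC(F)(F)F)c(Cl)c1` differs from compound 1 by cyclopropyl in place of ethyl on an aromatic nitrogen. Within the data shown here, no measured step bears on this change, so compound 4 is expected to stay close to compound 1, with a step of a 1.2-fold lower number from compound 1 to compound 4 (0.09 log units; within the scatter) that may well fall within the scatter. Compound 4 is estimated at 160 nM, between 60 nM and 500 nM.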

Compound 4, half-maximal inhibitory concentration in the sphingosine 1-phosphate receptor 2 assay: 218 nM
Compound 4: the middle estimate sits 1.4-fold (0.13 log units) below what was measured; the range from low to high includes it.
By their numbers in the sphingosine 1-phosphate receptor 2 assay, from the lowest: compound 3; then compound 2; then compounds 1 and 4 (each within the scatter of the next).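

On the aromatic nitrogen of the shared core, cyclopropyl in place of ethyl leaves the sphingosine 1-phosphate receptor 2 assay without a change beyond the scatter, with a 1.1-fold higher number from compound 1 to compound 4 (0.04 log units; within the scatter). In the sphingosine 1-phosphate receptor 2 assay compound 1 gives 199 nM and compound 4 gives 218 nM. In a physicochemical assay for lipophilicity, at pH 7.4 (on this read-out higher numbers stand for higher lipophilicity and lower numbers for lower lipophilicity), compound 1 gives 5.42 and compound 4 gives 5.43. In the physicochemical assay the same change gives a number 0.01 log units higher from compound 1 to compound 4 (within the scatter), so the three-membered ring is tolerated on both read-outs. Nothing shown accounts for this result.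

From the compounds shown here alone, a longer chain or an amine on this aromatic nitrogen remains open in both read-outs. So does whether the same change would behave alike in compounds carrying the carboxylic acid of compound 2 and compound 3.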